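The compounds below may be only part of what the source reports. "The series", "measured", "known", "first", "only" and "open" are said of these compounds alone.

In a functional assay on MDA-MB-231 cells (Homo sapiens) for antiproliferative activity, read by MTT assay, with a stated time of 72 h (on this read-out higher numbers stand for weaker inhibition and lower numbers for stronger inhibition), compound 1 `CC(=O)O[C@H]1CC[C@]2(C)[C@H](CC[C@@](C)(O)[C@H]2CC[C@@H]2C(C)=CC[C@H]3[C@H](CC[C@]3(C)O)C2(C)C)OC1(C)C` gives 38000 nM, compound 2 `CC1=CC[C@H]2[C@H](CC[C@]2(C)O)C(C)(C)[C@@H]1CC[C@H]1[C@]2(C)CC[C@H](OC(=O)c3ccc([N+](=O)[O-])cc3)C(C)(C)O[C@H]2CC[C@@]1(C)O` gives 8900 nM, and compound 3 `CC1=CC[C@H]2[C@H](CC[C@]2(C)O)C(C)(C)[C@@H]1CC[C@H]1[C@]2(C)CC[C@H](OC(=O)c3cccc(C(F)(F)F)c3)C(C)(C)O[C@H]2CC[C@@]1(C)O` gives 36300 nM. Compound 3 therefore shares the higher range with compound 1, as the data show a 1.0-fold lower number from compound 1 to compound 3 (0.02 log units; within the scatter). Against the remaining value, they show a 4.1-fold higher number from compound 2 to compound 3 (0.61 log units; beyond the scatter), and the earlier change gave a 4.3-fold lower number from compound 1 to compound 2 (0.63 log units; beyond the scatter). Compound 4 `CC1=CC[C@H]2[C@H](CC[C@]2(C)O)C(C)(C)[C@@H]1CC[C@H]1[C@]2(C)CC[C@H](OC(=O)c3ccccc3F)C(C)(C)O[C@H]2CC[C@@]1(C)O` has 2-fluorophenyl in place of 3-(trifluoromethyl)phenyl on a carbonyl carbon. Changes at this carbon have ranged from nothing beyond the scatter to modest, so at most a modest, downward step is expected in this assay. The expected step is a 1.7-fold lower number from compound 3 to compound 4 (0.22 log units; within the scatter). For compound 4, the estimated value is 22000 nM, with an expected range of 9000 nM to 48000 nM.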

Compound 4, half-maximal inhibitory concentration: 28700 nM
Estimate against measurement, compound 4: 1.3-fold (0.12 log units) below, and the stated range covers the measured number.
By their numbers in this assay, from the lowest: compound 2; then compounds 4, 3 and 1 (each within the scatter of the next).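

In this assay a third aromatic group, 2-fluorophenyl, gives a 1.3-fold lower number from compound 3 to compound 4 (0.10 log units; within the scatter) and a 1.3-fold lower number from compound 1 to compound 4 (0.12 log units; within the scatter) and so stays within the scatter of both, while a 3.2-fold higher number from compound 2 to compound 4 (0.51 log units; beyond the scatter) keeps it apart from the 4-nitrophenyl ester. A phenyl ring on this carbonyl carbon therefore does not by itself move the number away from that of the methyl compound, and among the compounds shown, only compound 2 differs from compound 1 beyond the scatter. No evidence here explains that difference. Still open, going by these compounds, is whether 3-nitrophenyl would match 4-nitrophenyl, and how a phenyl ring carrying an amine or a carboxylic acid would compare.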